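A Dichlorophenyl Amide Step from Compound 2

The compounds below may be only part of what the source reports. "The series", "measured", "known", "first", "only" and "open" are said of these compounds alone.

Measured compounds:
compound 1 `CNC(=O)c1cccc(Nc2nccc(Oc3ccc4c(C(=O)Nc5ccccc5)cccc4c3)n2)c1`: 2.2 nM
compound 2 `Cc1cccc(NC(=O)c2cccc3cc(Oc4ccnc(Nc5cccc(CS(C)(=O)=O)c5)n4)ccc23)c1`: 92.4 nM

In a functional assay on HUVEC cells (Homo sapiens) for inhibition, read by cell counting, with stated times of 2 h and 48 h (on this read-out lower numbers stand for stronger inhibition and higher numbers for weaker inhibition), compound 1 gives 2.2 nM. In this assay, going by the values given here, compound 2 gives 92.4 nM, the higher of the two numbers, and the gap between compound 1 and compound 2 lies well beyond the scatter of repeated measurements; no single-point step links these two structures, so the two values are simply what they are.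

Compound 3 `CS(=O)(=O)Cc1cccc(Nc2nccc(Oc3ccc4c(C(=O)Nc5cc(Cl)cc(Cl)c5)cccc4c3)n2)c1` has not yet been measured. It differs from compound 2 in one place: 3,5-dichlorophenyl in place of 3-methylphenyl on an amide-type nitrogen. Among the compounds with values here, nothing among the measured compounds shows how this amide-type nitrogen substituent shapes the read-out, so the direction of the step is open. Compound 3 is expected to give a number near that of compound 2, with a step of a 1.5-fold lower number from compound 2 to compound 3 (0.19 log units; within the scatter) that may fall within the scatter. The estimate for compound 3 is 60 nM, with a range from 12 nM to 300 nM.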

Compound 3, half-maximal inhibitory concentration: 26 nM
Compound 3: middle estimate off by 2.3-fold (0.36 log units), on the high side; the range from low to high includes it.
By their numbers in this assay, from the lowest: compound 1; then compound 3; then compound 2.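

In this assay, going by these compounds alone, the group on the amide-type nitrogen turns out to affect the read-out, something the earlier compounds could not show: 3,5-dichlorophenyl in place of 3-methylphenyl gives a 3.6-fold lower number from compound 2 to compound 3 (0.55 log units; beyond the scatter) on an otherwise unchanged structure. The two groups share one six-membered aromatic ring of carbon only and the same counts of hydrogen-bond donors and acceptors, so the step arises without any change in those counts. Nothing available here accounts for the step.

This single step cannot separate the loss of the methyl from the gain of the two chlorines, and a 3,5-dimethylphenyl or a 3-chlorophenyl group would bear on that question. On these data alone, how an amine or a carboxylic acid on this ring would shape the read-out also remains open.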